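Two Drawn Configurations and an Unassigned Stereocentre

The source may report more compounds than this note shows. Statements on the series, on what has been measured and on what is new or still open speak of the compounds shown alone.

compound 1 `CC1=CS[C@@](OCC(F)(F)F)(c2ccc(Br)cc2)c2noc(=O)n21`: 34 nM
compound 2 `CC1=CS[C@](OCC(F)(F)F)(c2ccc(Br)cc2)c2noc(=O)n21`: 26 nM

In a functional assay on cardiac atrium with Left cardiac atrium (Cavia porcellus) as the target (on this read-out higher numbers stand for an effect only at larger amounts of compound and lower numbers for an effect already at smaller amounts), compound 1 gives 34 nM and compound 2 gives 26 nM; the two numbers lie within the scatter of one another. Their structures share all atoms and bonds (the fact that compounds 1 and 2 differ only in the configuration as drawn), and the step of a 1.3-fold lower number from compound 1 to compound 2 (0.12 log units; within the scatter) shows this. Compound 3 `CC1=CSC(OCC(F)(F)F)(c2ccc(Br)cc2)c2noc(=O)n21` again keeps every atom and bond; (the two compounds have the same atoms and bonds; at least one stereo element is drawn with a configuration in one of them and without one in the other: 1 of 1 stereo elements differ; a stereocentre at a saturated ring carbon is drawn S in compound 1 and without a configuration in compound 3). Because the step of a 1.3-fold lower number from compound 1 to compound 2 (0.12 log units; within the scatter) stays within the scatter, no shift beyond it is expected on going from compound 1 to compound 3. The expected step is a 1.1-fold lower number from compound 1 to compound 3 (0.05 log units; within the scatter). Compound 3 is therefore estimated at 30 nM, with a range from 15 nM to 60 nM.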

Compound 3, half-maximal effective concentration: 22 nM
Estimate against measurement, compound 3: 1.4-fold (0.13 log units) above; low and high end bracket the measured number.
By their numbers in this assay, from the lowest: compounds 3, 2 and 1 (each within the scatter of the next).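

In this assay, setting the drawing without a configuration at this saturated ring carbon against each drawn form gives a 1.5-fold lower number from compound 1 to compound 3 (0.19 log units; within the scatter) and a 1.2-fold lower number from compound 2 to compound 3 (0.07 log units; within the scatter). All three drawings of this stereocentre, S, R and without a configuration, now lie within the scatter of one another, so compound 3 does not stand apart from either compound 1 or compound 2. The compounds shown vary only how this carbon is drawn, not what is attached to it. On these data alone, whether the numbers would hold with an amine or a carboxylic acid attached at this carbon stays open.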